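Removing the fluoro group from compound 2

The source may hold more compounds than are shown below. What is called first, only, known or untested is meant among the compounds shown, and "the series" means these compounds.

Measured in a functional assay on A549 cells (Homo sapiens) for cytotoxicity, read by WST assay, with a stated time of 24 h; a lower number here means a stronger inhibitor, a higher number a weaker inhibitor:
Compound 1 `COc1ccc2c(/C=C(\C#N)C(=O)c3c[nH]c4cc(OC)ccc34)c[nH]c2c1`: 1900 nM
Compound 2 `N#C/C(=C\c1cn(Cc2ccc(Cl)cc2)c2ccccc12)C(=O)c1c[nH]c2cc(F)ccc12`: > 50000 nM
Compound 3 `COc1ccc2c(C(=O)/C(C#N)=C/c3c[nH]c4cc(F)ccc34)c[nH]c2c1`: 2400 nM

Compound 2 gives > 50000 nM in this assay, and this is a limit of the assay, not a number. No numerical starting point therefore exists for the step under study.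

The step leads to compound 4 `N#C/C(=C\c1cn(Cc2ccc(Cl)cc2)c2ccccc12)C(=O)c1c[nH]c2ccccc12`, and the structural change is hydrogen in place of fluoro on an aromatic carbon. In words, hydrogen stands in place of fluoro on an aromatic carbon.

Among the measured compounds shown here, only one measured step bears on this: a 1.3-fold higher number from compound 1 to compound 3 (0.10 log units; within the scatter). It puts fluoro in place of methoxy on an aromatic carbon and lies within the scatter. It is a different exchange, made on compounds that differ from compound 2 elsewhere, so it offers only indirect guidance. No step beyond the scatter is expected in this assay, and another report as a limit is likely.

The expected step is a number no higher from compound 2 to compound 4 (the limit leaves the size open).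

For compound 4 the estimate is 50000 nM, with an expected range from 15000 nM to 100000 nM.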

Compound 4, half-maximal inhibitory concentration: > 50000 nM
Compound 4: a limit, no number; the forecaster's own chance of this, stated with the estimate: 60%; the middle value lies on the limit itself.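

Compound 4 gives > 50000 nM, a limit of the assay and not a number. Compound 2 is also a limit, so no step can be read from compound 2 to compound 4. The compounds shown leave open whether hydrogen in place of fluoro changes anything in this pair: the limit of > 50000 nM in this assay, at which 2 of the 4 values shown sit.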